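The source may report more compounds than this note shows. Statements on the series, on what has been measured and on what is new or still open speak of the compounds shown alone.

Measured in an ADME assay on L929 cells (Mus musculus) for cytotoxicity, read by resazurin assay, with a stated time of 96 h (a lower number here means that less compound is tolerated, a higher number that more compound is tolerated), are three compounds:
Compound 1 `NC(=S)N/N=C(\COc1ccccc1)c1ccc(Br)cc1` gives 54900 nM
Compound 2 `CC(=O)Nc1ccc(OC/C(=N\NC(N)=S)c2ccc(Br)cc2)cc1` gives 94900 nM
Compound 3 `NC(=S)N/N=C(\COc1ccc(Cl)cc1)c1ccc(Br)cc1` gives < 25100 nM as a limit

For compound 3 the value < 25100 nM is a limit of the assay and not a number. Its true place is therefore known only from that limit and from the steps that lead to it.

Compound 4 `NC(=S)N/N=C(\COc1ccc(I)cc1)c1ccc(Br)cc1` has not yet been measured. It carries iodo in place of chloro on an aromatic carbon and the group sits para to a large group.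

For the measured compounds named here, no measured step exchanges one halogen for another. The closest evidence is an at least 2.1-fold lower number from compound 1 to compound 3 (0.33 log units; beyond the scatter) for chloro in place of hydrogen and an at least 3.7-fold lower number from compound 2 to compound 3 (0.57 log units; beyond the scatter) for chloro in place of acetamido. Both lie beyond the scatter. In contrast a 1.7-fold higher number from compound 1 to compound 2 (0.24 log units; within the scatter) for acetamido in place of hydrogen stays within it.

Compound 4 keeps a halogen at the same place, so no step beyond the scatter is expected. The expected change is a step that the limit leaves unreadable from compound 3 to compound 4 and it is estimated against a limit, so it is only a rough guide. In this assay the estimate for compound 4 is 20000 nM with 8000 nM to 45000 nM as the range expected.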

Compound 4, half-maximal cytotoxic concentration: < 20400 nM
Compound 4: a limit, no number; the forecaster's own chance of this, stated with the estimate: 40%; the middle value does not contradict the limit.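

In this assay compound 4, which carries the 4-iodophenyl group, gives only a limit, < 20400 nM, so a second halogen at this place, para to a large group, also ends at a limit and not at a number. Iodo in place of hydrogen gives an at least 2.6-fold lower number from compound 1 to compound 4 (0.42 log units; beyond the scatter), and iodo in place of acetamido gives an at least 4.6-fold lower number from compound 2 to compound 4 (0.66 log units; beyond the scatter), so among the compounds shown, the lower number seen with chloro is not confined to chloro. Compound 3 and compound 4 both stand at limits, and the step between them cannot be read, so the exchange of chloro for iodo itself shows no size or direction.

As far as these compounds go, how far either halogen compound lies under its limit remains open, and with it whether iodo and chloro differ at all. Also open, from the compounds shown here alone, is whether fluoro, a methoxy group or an amine at the same place would join the two halogens at the low end or stand with the hydrogen and acetamido compounds, compound 1 and compound 2.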